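A few compounds are considered here, and "the series" means these few. Any claim that something is new, unique, unknown or untested is made for them only; others in the source may bear on it.

Of the compounds shown here, three of one series have been measured in a functional assay on HeLa cells (Homo sapiens) for cytotoxicity, read by MTT assay, with a stated time of 48 h; a higher number here means a weaker inhibitor, a lower number a stronger inhibitor. Compound 1 `COc1ccc(-c2cc(C(=O)Nc3nc4ccc(Cl)cc4s3)nc3cc(-c4ccccc4)nn23)cc1OC` gives 9120 nM, compound 2 `COc1ccc2nc(NC(=O)c3cc(-c4ccc(OC)c(OC)c4)n4nc(-c5ccccc5)cc4n3)sc2c1` gives 11000 nM, and compound 3 `COc1ccc(-c2cc(C(=O)Nc3nc4ccccc4s3)nc3cc(-c4ccccc4)nn23)cc1` gives 4670 nM. Compound 3 thus shows the lowest of the three numbers, though its gap to compound 1 lies within the scatter and only its gap to compound 2 lies beyond it. For the measured compounds named here, the one single-point step measured so far, a 1.2-fold higher number from compound 1 to compound 2 (0.08 log units; within the scatter), is a change of a different kind.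

Compound 4 `COc1ccc(-c2cc(C(=O)Nc3nc4ccccc4s3)nc3cc(-c4ccccc4)nn23)cc1OC` differs from compound 3 by methoxy in place of hydrogen on an aromatic carbon. Going by the values given here, no measured step isolates this change. What the numbers do show is that compound 1 and compound 2, both carrying the 3,4-dimethoxyphenyl group, sit at higher numbers than compound 3 with its 4-methoxyphenyl group, while differing from it in a second place as well. Taking that as the only guide, a modest rise is expected, a 1.5-fold higher number from compound 3 to compound 4 (0.18 log units; within the scatter). Compound 4 is therefore estimated at 7000 nM, in the range 3000 nM to 16000 nM.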

Compound 4, half-maximal inhibitory concentration: 8910 nM
Compound 4: middle estimate off by 1.3-fold (0.10 log units), on the low side; measured number inside the range.
By their numbers in this assay, from the lowest: compounds 3, 4, 1 and 2 (each within the scatter of the next, the first and the last beyond it).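

In this assay the change from 4-methoxyphenyl to 3,4-dimethoxyphenyl now has a measured step of its own (a 1.9-fold higher number from compound 3 to compound 4 (0.28 log units; within the scatter)), and that step lies within the scatter, so a methoxy added at this position, ortho to a methoxy group, gives no change that can be told from repeat scatter. Compound 4 also gives the second place of difference a direct reading (a 1.2-fold lower number from compound 2 to compound 4 (0.09 log units; within the scatter)) (a 1.0-fold lower number from compound 1 to compound 4 (0.01 log units; within the scatter)), and with both steps within the scatter, hydrogen, methoxy and chloro on that aromatic carbon cannot be told apart. Nothing measured beyond these numbers bears on the result.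

The compounds shown leave open whether a group of another kind at the first position, such as an amine or a carboxylic acid, would give a step beyond the scatter. The same question stands for a longer chain such as butoxy in place of the added methoxy.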